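Swapping a Furan for a Pyridine at the Benzylic Amine

This account rests on a few compounds, and the source may have more. Where it says the series, first, only, none or still open, it means among the compounds named here.

Compound 1 `c1ccc(CNCC2CCN(CCCc3c[nH]c4ccc(-n5cnnc5)cc34)CC2)cc1`: 28 nM
Compound 2 `c1ccc2c(c1)CCC2NC1CCN(CCCc2c[nH]c3ccc(-n4cnnc4)cc23)CC1`: 280 nM
Compound 3 `c1cc(CNC2CCN(CCCc3c[nH]c4ccc(-n5cnnc5)cc34)CC2)co1`: 78 nM

In an assay on CHO cells for displacement of a labelled ligand from 5-hydroxytryptamine receptor 1B (Homo sapiens) (on this read-out higher numbers stand for weaker inhibition and lower numbers for stronger inhibition), compound 3 stands second of the three, giving 78 nM. The nearest is compound 1, which gives 28 nM; the step of a 2.8-fold higher number from compound 1 to compound 3 (0.44 log units; beyond the scatter). Compound 2 gives 280 nM, and the step of a 3.6-fold lower number from compound 2 to compound 3 (0.56 log units; beyond the scatter). Compound 4 `c1cncc(CNC2CCN(CCCc3c[nH]c4ccc(-n5cnnc5)cc34)CC2)c1` differs from compound 3 by pyridin-3-yl in place of furan-3-yl on a saturated chain carbon bound to an amine nitrogen. Within the data shown here, no measured step covers this exact exchange; the closest guide is compound 1, whose six-membered aromatic ring gave the lowest number, as the step of a 2.8-fold higher number from compound 1 to compound 3 (0.44 log units; beyond the scatter) shows. A small move toward that value, or none beyond the scatter, is therefore expected. Compound 4 is estimated at 50 nM, within 20 nM to 150 nM, an expected step of a 1.6-fold lower number from compound 3 to compound 4 (0.19 log units; within the scatter).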

Compound 4, half-maximal inhibitory concentration: 140 nM
Beside the measured number, compound 4's estimate is 2.8-fold (0.45 log units) below it; the range from low to high includes it.
By their numbers in this assay, from the lowest: compound 1; then compounds 3, 4 and 2 (each within the scatter of the next, the first and the last beyond it).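

Exchanging furan-3-yl for pyridin-3-yl gives a 1.8-fold higher number from compound 3 to compound 4 (0.25 log units; within the scatter), so at this place the six-membered aromatic ring does not stand apart from the five-membered one. The (pyridin-3-yl)methyl group likewise stays close to 2,3-dihydro-1H-inden-1-yl, with a 2.0-fold lower number from compound 2 to compound 4 (0.30 log units; within the scatter), whereas ((pyridin-3-yl)methyl)amino in place of (benzylamino)methyl gives a 5.0-fold higher number from compound 1 to compound 4 (0.70 log units; beyond the scatter), so a six-membered aromatic ring alone does not recover the value of compound 1. No measurement shown here explains these numbers.

As far as these compounds go, it remains open whether the gap to compound 1 follows the ring nitrogen or the extra methyl-derived link in (benzylamino)methyl. A plain benzylamino group on the saturated ring carbon would separate the two.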